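This account rests on a few compounds, and the source may have more. Where it says the series, first, only, none or still open, it means among the compounds named here.

Series notes. Compound 1 `O=c1oc2ccc(I)cc2c(=O)n1-c1ccc(Cl)cc1F` and compound 3 `O=c1oc2ccc(I)cc2c(=O)n1-c1ccc(Br)cc1F` share one core; compound 2 `O=C(Nc1ccc(Br)cc1F)c1cc(Br)ccc1O` and compound 4 `O=C(Nc1ccc(Br)cc1F)c1cc(Cl)ccc1O` share another, and the difference between the two cores is not broken down here. In an ADME assay on RAW264.7 cells (Mus musculus) for cytotoxicity, read by MTT assay, with a stated time of 24 h (on this read-out higher numbers stand for lower toxicity in this test and lower numbers for higher toxicity in this test), compound 1 gives 8900 nM; compound 3 gives 8300 nM; compound 2 gives 7800 nM. The three numbers sit within the scatter of one another. Among the compounds with values here, the one change measured so far is chloro in place of bromo on an aromatic carbon, which gave a 1.1-fold higher number from compound 3 to compound 1 (0.03 log units; within the scatter). Compound 4 carries the same kind of change, (chloro in place of bromo on an aromatic carbon), though the surroundings of the place are not the same: in compound 1 the carbon is meta to a fluoro group and para to a large group, while in compound 4 it is meta to a large group and para to a hydroxy group. From compound 2 to compound 4 a step of a 1.1-fold higher number from compound 2 to compound 4 (0.04 log units; within the scatter) is expected in this assay. Within the data shown here, this rests on the single measured instance of the change, a 1.1-fold higher number from compound 3 to compound 1 (0.03 log units; within the scatter), which stays within the scatter. Compound 4 is estimated at 8500 nM, with a range from 4500 nM to 16000 nM.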

Compound 4, half-maximal cytotoxic concentration: 7800 nM
The estimate for compound 4 lay 1.1-fold (0.04 log units) above the measured number, and the stated range covers the measured number.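

Chloro in place of bromo on an aromatic carbon gives no change at the digits printed from compound 2 to compound 4 (within the scatter) in this assay. Set beside the earlier instance, the step on the core of compound 2 cannot be told apart from the step on the core of compound 1: the same change on two cores in this assay, a 1.1-fold higher number (0.03 log units; within the scatter) from compound 3 to compound 1 and no change at the digits printed (within the scatter) from compound 2 to compound 4, 1.1-fold (0.03 log units) apart, within the scatter of two such steps. This supports carrying the change between these two cores in this assay as a step that stays within the scatter, but it rests on only two instances, at places with different surroundings, and it gives no reason for the result and no basis for extending it to other cores or other read-outs.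

Open, on these data alone, is whether anything other than a halogen at the place para to a hydroxy group would move the number beyond the scatter, for example an amine, a carboxylic acid or a longer chain such as propyl. The compounds shown also leave open how a methoxy group in place of the hydroxy group of compound 4 would read in this assay.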